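The compounds below may be only part of what the source reports. "The series", "measured", "known", "first", "only" and "open" are said of these compounds alone.

Compound 1 `Cc1nccn1-c1csc(Nc2ccc(S(N)(=O)=O)cc2)n1` and compound 2 `Cc1nccn1-c1csc(Nc2ccccc2)n1` are built on one shared core, while compound 3 `Cc1nc2ccccc2n1-c1csc(Nc2ccc(S(N)(=O)=O)cc2)n1` and compound 4 `Cc1nc2ccccc2n1-c1csc(Nc2ccccc2)n1` are built on another; the difference between the two cores is not broken down here. In a functional assay on RKO cells (Homo sapiens) for cytotoxicity, read by resazurin assay, with a stated time of 72 h (a lower number here means a stronger inhibitor, a higher number a weaker inhibitor), compound 1 gives 49000 nM, compound 2 gives 32500 nM and compound 3 gives 45000 nM. From compound 1 to compound 2 the change is hydrogen in place of sulfamoyl on an aromatic carbon, and that gave a 1.5-fold lower number from compound 1 to compound 2 (0.18 log units; within the scatter). Compound 4 has not been measured yet; from compound 3 to compound 4 the same change is made (hydrogen in place of sulfamoyl on an aromatic carbon), so it appears twice among these compounds. Because a 1.5-fold lower number from compound 1 to compound 2 (0.18 log units; within the scatter) stayed within the scatter, the step expected for compound 4 in this assay is a 1.4-fold lower number from compound 3 to compound 4 (0.13 log units; within the scatter). The estimate for compound 4 is 33000 nM, most likely falling between 15000 nM and 70000 nM.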

Compound 4, half-maximal inhibitory concentration: 40000 nM
For compound 4 the middle estimate is 1.2-fold (0.08 log units) below the measured one, and the stated range covers the measured number.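

Putting hydrogen in place of sulfamoyl gave a 1.1-fold lower number from compound 3 to compound 4 (0.05 log units; within the scatter) in this assay, and the two cores agree on this step: the same change on two cores in this assay, a 1.5-fold lower number (0.18 log units; within the scatter) from compound 1 to compound 2 and a 1.1-fold lower number (0.05 log units; within the scatter) from compound 3 to compound 4, 1.3-fold (0.13 log units) apart, within the scatter of two such steps

So the change carries from one core to the other in the sense that it leaves the number within the scatter on both. It does not show a shared real effect, since neither step can be told apart from repeat-measurement noise, and two such small steps would match whether or not the cores respond alike.

Still open, going by these compounds, is whether a different group in that place, such as an amine or a carboxylic acid, would move the number beyond the scatter, and whether it would do so equally on both cores.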